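The source may report more compounds than this note shows. Statements on the series, on what has been measured and on what is new or still open speak of the compounds shown alone.

Compounds measured in an assay on isolated protein for inhibition of phosphodiesterase 4A (Sus scrofa); a lower number here means a stronger inhibitor, a higher number a weaker inhibitor:
Compound 1, `COc1ccc(C(=O)Nc2ccccc2Br)cc1OC1CCCC1`, gives 130 nM.
Compound 2, `COc1ccc(C(=O)Nc2ccccn2)cc1OC1CCCC1`, gives 1000 nM.

Compound 2 stands at the highest of the two numbers in this assay; its nearest neighbour is compound 1, and the change on the amide-type nitrogen gave a 7.7-fold higher number from compound 1 to compound 2 (0.89 log units; beyond the scatter). Compound 3, `COc1ccc(C(=O)Nc2cccnc2)cc1OC1CCCC1`, is not yet measured. It differs from compound 2 only in the group on the amide-type nitrogen: pyridin-3-yl in place of pyridin-2-yl on an amide-type nitrogen. For the measured compounds named here, no measured step covers this exchange directly; the single measured step, from compound 1 to compound 2, concerns a different group and shows only that the aryl group on the amide-type nitrogen can move the number modestly. For compound 3 a step of a 1.4-fold lower number from compound 2 to compound 3 (0.15 log units; within the scatter) is therefore expected in this assay, a modest decrease at most, not clearly beyond the scatter. Compound 3 is estimated at 700 nM, with a range from 200 nM to 2500 nM.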

Compound 3, half-maximal inhibitory concentration: 550 nM
The estimate for compound 3 lay 1.3-fold (0.10 log units) above the measured number, within the range that was stated.
By their numbers in this assay, from the lowest: compound 1; then compounds 3 and 2 (each within the scatter of the next).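

In this assay the exchange of pyridin-2-yl for pyridin-3-yl on the amide-type nitrogen gave a 1.8-fold lower number from compound 2 to compound 3 (0.26 log units; within the scatter) and so cannot be told apart from the scatter; the two pyridine compounds cannot be put in order. The second replacement of 2-bromophenyl, read as a 4.2-fold higher number from compound 1 to compound 3 (0.63 log units; beyond the scatter), also lies beyond the scatter, so compound 1 keeps the lower number against both pyridine compounds. Nothing at hand explains these numbers.

Going by these compounds, how an unsubstituted phenyl, a 2-chlorophenyl or a pyridin-4-yl group on the same nitrogen would stand remains open. These three compounds also cannot separate the part played by the bromine from that of the ring nitrogen, since compound 1 differs from compound 2 and compound 3 in both.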